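This account rests on a few compounds, and the source may have more. Where it says the series, first, only, none or still open, it means among the compounds named here.

Measured in a functional assay on MCF7 cells (Homo sapiens) for antiproliferative activity, read by MTT assay, with a stated time of 72 h; on this read-out lower numbers stand for stronger inhibition and higher numbers for weaker inhibition:
Compound 1 `C/C(=N\NC(=O)c1cccc(S(=O)(=O)N2CCOCC2)c1)c1ccccc1O`: 5400 nM
Compound 2 `C/C(=N\NC(=O)c1cccc(S(=O)(=O)N2CCOCC2)c1)c1cc(O)ccc1O`: > 100000 nM (a limit)
Compound 3 `O=C(N/N=C/c1ccccn1)c1cccc(S(=O)(=O)N2CCOCC2)c1`: > 100000 nM (a limit)

Compound 3 reads > 100000 nM, which is a limit and not a number. This is the limit of > 100000 nM in this assay, at which 2 of the 3 values shown sit.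

Compound 4 `O=C(N/N=C/c1cc(Cl)ccc1O)c1cccc(S(=O)(=O)N2CCOCC2)c1` differs from compound 3 at one place: 5-chloro-2-hydroxyphenyl in place of pyridin-2-yl on a carbon with a double bond to nitrogen. In words, 5-chloro-2-hydroxyphenyl stands in place of pyridin-2-yl on a carbon with a double bond to nitrogen.

Among the measured compounds shown here, only one measured step bears on this change, and only loosely. A further hydroxy on the aromatic ring gave an at least 18-fold higher number from compound 1 to compound 2 (1.26 log units; beyond the scatter), a large loss, so a new group on a hydroxy-bearing ring can cost a great deal. No chlorine has been measured here. Even so, compound 4 keeps a hydroxy-bearing ring like that of compound 1, which gives 5400 nM in this assay.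

A large move towards stronger inhibition is therefore expected, estimated as an at least 10-fold lower number from compound 3 to compound 4 (1.00 log units; beyond the scatter). For compound 4 the estimated value is 10000 nM, with an expected range of 2000 nM to 60000 nM.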

Compound 4, half-maximal inhibitory concentration: 16500 nM
The estimate for compound 4 lay 1.7-fold (0.22 log units) below the measured number; measured number inside the range.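

In this assay, the group on the carbon with a double bond to nitrogen clearly matters: 5-chloro-2-hydroxyphenyl in place of pyridin-2-yl gives an at least 6.0-fold lower number from compound 3 to compound 4 (0.78 log units; beyond the scatter). Among the compounds shown here, the only earlier step was a loss, so this is the first sign that a change to an aromatic ring can move towards stronger inhibition. From the compounds shown here alone, the true size of the step stays unknown because compound 3 stands at a limit: the limit of > 100000 nM in this assay, at which 2 of the 4 values shown sit.

The step replaces the pyridine nitrogen and adds a hydroxy and a chlorine all at once, and the compounds shown do not tell which of these changes carries it. Going by these compounds, it also remains open whether a methoxy in place of the hydroxy, or a bromine or an amine in place of the chlorine, would keep the gain.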